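The source may report more compounds than this note shows. Statements on the series, on what has been measured and on what is new or still open speak of the compounds shown alone.

Compound 3 `CCCN(CC[C@H]1CC[C@H](NS(=O)(=O)c2ccccc2)CC1)[C@H]1CCc2nc(N)sc2C1` carries a phenylsulfonyl group on the amine nitrogen of the shared core. In an assay on brain for displacement of a labelled ligand from D(3) dopamine receptor (Rattus norvegicus) (on this read-out lower numbers stand for stronger inhibition and higher numbers for weaker inhibition), compound 3 gives 0.79 nM. Two other compounds share this core. Compound 1 `CCCN(CC[C@H]1CC[C@H](NC(=O)/C=C/c2cccc(Cl)c2)CC1)[C@H]1CCc2nc(N)sc2C1`, which bears a (2-(3-chlorophenyl)ethenyl)carbonyl group on that nitrogen instead, gives 1.2 nM in this assay. Compound 2 `CCCN(CC[C@H]1CC[C@H](NS(=O)(=O)c2cccc3ccccc23)CC1)[C@H]1CCc2nc(N)sc2C1` carries a naphthalen-1-yl group on the sulfonyl sulfur in place of the phenyl of compound 3; in this assay compound 2 gives 1.5 nM. Compound 3 has the lowest of the three numbers, but the steps leading to it, a 1.5-fold lower number from compound 1 to compound 3 (0.18 log units; within the scatter) and a 1.9-fold lower number from compound 2 to compound 3 (0.28 log units; within the scatter), both stay within the usual scatter, so the three compounds cannot be told apart on these numbers.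

Compound 4 `CCCN(CC[C@H]1CC[C@H](NS(=O)(=O)c2ccc(-c3ccccc3)cc2)CC1)[C@H]1CCc2nc(N)sc2C1` differs from compound 3 in one place: phenyl in place of hydrogen on an aromatic carbon. Among the compounds with values here, the step that bears most closely on this is the one from compound 2 to compound 3, where a larger aromatic group on the sulfonyl sulfur gave way to phenyl without a change beyond the scatter. Enlarging the aromatic group again is therefore expected to move this assay little, if at all, and the estimated step is a 1.3-fold higher number from compound 3 to compound 4 (0.10 log units; within the scatter). Compound 4 is thus expected to give about 1 nM, within a range from 0.3 nM to 3.5 nM.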

Compound 4, inhibition constant: 41 nM
The estimate for compound 4 lay 41-fold (1.61 log units) below the measured number; measured number outside the range, above it.
By their numbers in this assay, from the lowest: compounds 3, 1 and 2 (each within the scatter of the next); then compound 4.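

In this assay, putting a phenyl on this aromatic carbon gives a 52-fold higher number from compound 3 to compound 4 (1.72 log units; beyond the scatter), the first change among these compounds to lie beyond the scatter, so this carbon is far less forgiving than the near-identical numbers of the earlier compounds suggested. The comparison of the two larger groups on the sulfonyl sulfur gives a 27-fold higher number from compound 2 to compound 4 (1.44 log units; beyond the scatter), and since naphthalen-1-yl stayed within the scatter of plain phenyl, the presence of a larger aromatic group does not decide the outcome; which larger group it is matters, and 4-phenylphenyl is the one that goes against the flat picture. Why the added ring raises the number so sharply finds no explanation in any measurement available here.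

One open question is whether a single methyl or a chlorine atom on this same carbon would already raise the number, or whether it takes a whole added ring. Going by these compounds, it is also open whether a phenyl placed on another carbon of that ring, or a methoxy group or an amine on this carbon, would behave like the phenyl of compound 4.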